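The source may report more compounds than this note shows. Statements on the series, on what has been measured and on what is new or still open speak of the compounds shown alone.

Measured in a functional assay on MCF7 cells (Homo sapiens); on this read-out lower numbers stand for stronger inhibition and higher numbers for weaker inhibition:
Compound 1 `COc1cc(NC(C)CCCNC(=O)NCCCO)c2ncccc2c1`: 31000 nM
Compound 2 `COC(=O)NCCCC(C)Nc1cc(OC)cc2cccnc12`: > 100000 nM

Compound 2 gives only a limit of the assay, > 100000 nM, and not a number. Compound 3 `CCOC(=O)NCCCC(C)Nc1cc(OC)cc2cccnc12` differs from it by one small change, (methyl in place of hydrogen on a saturated chain carbon bound to an oxygen next to a carbonyl group), which turns methoxy into ethoxy. Going by the values given here, the one measured step, an at least 3.2-fold higher number from compound 1 to compound 2 (0.50 log units; beyond the scatter), lies beyond the scatter, but it replaced (3-hydroxypropyl)amino with methoxy on the carbonyl carbon, a much larger change. It ended at the limit: the limit of > 100000 nM in this assay, at which 1 of the 2 values shown sits. No step beyond the scatter is therefore expected in this assay, and another limit is likely. The expected step is a number no higher from compound 2 to compound 3 (the limit leaves the size open). For compound 3 the estimate is 100000 nM, with an expected range of 40000 nM to 200000 nM.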

Compound 3, half-maximal inhibitory concentration: 26000 nM
Compound 3: middle estimate off by 3.8-fold (0.59 log units), on the high side, and the stated range ends above it.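

On the carbonyl carbon, a very small change can count: in this assay, one added methyl, which turns methoxy into ethoxy, gives an at least 3.8-fold lower number from compound 2 to compound 3 (0.58 log units; beyond the scatter). Ethoxy in place of (3-hydroxypropyl)amino on that carbon gives a 1.2-fold lower number from compound 1 to compound 3 (0.08 log units; within the scatter), so the two groups cannot be told apart on this read-out. Compound 2 gives a limit of the assay and not a number: the limit of > 100000 nM in this assay, at which 1 of the 3 values shown sits.

From the compounds shown here alone, whether a longer chain such as propoxy, or an amine such as dimethylamino, on the same carbonyl carbon would lower the number further remains open.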